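Methyl at the chain carbon and cytotoxicity on MT4 cells

This account rests on a few compounds, and the source may have more. Where it says the series, first, only, none or still open, it means among the compounds named here.

Measured compounds:
- compound 1, `CC(C)Sc1nc(O)cc(C(C)c2cccc3ccccc23)n1`, 119000 nM
- compound 2, `CCC(c1cc(O)nc(SC(C)C)n1)c1cccc2ccccc12`, 16900 nM
- compound 3, `CC(C)Sc1nc(O)cc(C(C)c2c(Cl)cccc2Cl)n1`, 117000 nM

All three were tested in a functional assay on MT4 cells (Homo sapiens) for cytotoxicity; on this read-out lower numbers stand for higher toxicity in this test and higher numbers for lower toxicity in this test. Compound 1 gives 119000 nM in this assay, and compound 2, which carries methyl in place of hydrogen on a saturated chain carbon, two bonds along the chain from two aromatic carbons, gives 16900 nM. That change made the step of a 7.0-fold lower number from compound 1 to compound 2 (0.85 log units; beyond the scatter), so compound 2 is the more toxic of the two in this test.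

Compound 3 gives 117000 nM. The difference between the core of compound 3 and the core of compound 1 is not broken down here. The numbers of compound 3 and compound 1 lie within the scatter of each other, while compound 2 sits apart from both.

Compound 4, `CCC(c1cc(O)nc(SC(C)C)n1)c1c(Cl)cccc1Cl`, is not yet measured. It differs from compound 3 by methyl in place of hydrogen on a saturated chain carbon, two bonds along the chain from two aromatic carbons, and the place of this change is described in the same words as for the change from compound 1 to compound 2, so it is the same kind of change on a different core. Within the data shown here, since this change appears only once among the measured compounds, the expectation for compound 4 rests on a single step, the one from compound 1 to compound 2. For compound 4 a step of about a 5.9-fold lower number from compound 3 to compound 4 (0.77 log units; beyond the scatter) in this assay is expected, because the earlier step was a 7.0-fold lower number from compound 1 to compound 2 (0.85 log units; beyond the scatter). Compound 4 is therefore estimated at 20000 nM, with a range from 7000 nM to 60000 nM.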

Compound 4, half-maximal cytotoxic concentration: > 200000 nM
Compound 4 gave a limit, no number; the forecaster's own chance of this, stated with the estimate: 5%; at least 10-fold (1.00 log units) between middle value and limit.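

In this assay, compound 4 reads as a limit of the assay and not as a number: the limit of > 200000 nM in this assay, at which 1 of the 4 values shown sits. Taken as a floor, the change from hydrogen to methyl gives an at least 1.7-fold higher number from compound 3 to compound 4 (0.23 log units; that floor lies within the scatter), so the number does not fall on this core as it did on the core of compound 1, and the two steps do not agree: the same change on two cores in this assay, a 7.0-fold lower number (0.85 log units; beyond the scatter) from compound 1 to compound 2 and an at least 1.7-fold higher number (0.23 log units; that floor lies within the scatter) from compound 3 to compound 4, at least 12-fold (1.08 log units) apart, beyond the scatter of two such steps. This shows that in this series the step seen on the core of compound 1 cannot simply be carried over to the core of compound 3, although it does not show how large the true step on the core of compound 3 is, why the two cores part ways, or which of the two behaviours would be the more common on a further core.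

Among these compounds, with only two pairs of compounds, the effect of the change on any other core remains open, and the result for compound 4 gives only a floor for its step. Also open, as far as these compounds go, is whether a longer chain such as propyl, or a chain carrying an amine, at the same saturated chain carbon would follow the pattern of the core of compound 1 or that of the core of compound 3.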